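Two anilinoquinazoline analogues measured, a third one awaited

This account rests on a few compounds, and the source may have more. Where it says the series, first, only, none or still open, it means among the compounds named here.

Measured compounds:
compound 1 `C#Cc1cccc(Nc2nc(Nc3ccc(Cl)c(C(F)(F)F)c3)nc3cc(OC)c(OC)cc23)c1` gives 6800 nM
compound 2 `C#Cc1cccc(Nc2nc(Nc3ccc(Oc4ccccc4)cc3)nc3cc(OC)c(OC)cc23)c1` gives 2800 nM

In a functional assay on SK-HEP1 cells (Homo sapiens) for inhibition, read by MTT assay, with a stated time of 48 h (on this read-out higher numbers stand for weaker inhibition and lower numbers for stronger inhibition), compound 1 has the highest number of the two. Compound 2 is the nearer of the pair and stands beyond the scatter from compound 1. Within the data shown here, no step between two measured compounds that differ in one place is known here. Compound 3 `C#Cc1cccc(Nc2nc(Nc3cccc(Cl)c3)nc3cc(OC)c(OC)cc23)c1` arises from compound 1 by 3-chlorophenyl in place of 4-chloro-3-(trifluoromethyl)phenyl on a nitrogen on an aromatic ring. Among the measured compounds shown here, no measured pair shows what this exchange does, so the expected step in this assay is a small one, of no certain direction and possibly none beyond the scatter. For compound 3 the estimate is 7500 nM, with a range from 2500 nM to 22000 nM, meaning an expected step of a 1.1-fold higher number from compound 1 to compound 3 (0.04 log units; within the scatter).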

Compound 3, half-maximal inhibitory concentration: 7100 nM
The estimate for compound 3 lay 1.1-fold (0.02 log units) above the measured number; measured number inside the range.
By their numbers in this assay, from the lowest: compound 2; then compounds 1 and 3 (each within the scatter of the next).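

In this assay, 3-chlorophenyl in place of 4-chloro-3-(trifluoromethyl)phenyl on a nitrogen on an aromatic ring gives a 1.0-fold higher number from compound 1 to compound 3 (0.02 log units; within the scatter). This first one-place comparison shows that, at this position on the shared core, the trifluoromethyl group can go and the chlorine can take a different place on the ring without a change beyond the scatter. No measurement here bears on why the number holds. From the compounds shown here alone, what an unsubstituted phenyl would give at this position remains open. So does the effect of an amine or a carboxylic acid on this ring.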